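The source may report more compounds than this note shows. Statements on the series, on what has been measured and on what is new or still open speak of the compounds shown alone.

Measured compounds:
compound 1 `CC(C)c1ccc(C(C)C)c(C(=O)/C=C/C(=O)O)c1` — 4750 nM
compound 2 `CC(C)(C)c1ccc(C(=O)/C=C/C(=O)O)cc1` — 5100 nM

In a functional assay on HeLa cells (Homo sapiens) for inhibition, read by MTT assay, with a stated time of 72 h (a higher number here means a weaker inhibitor, a lower number a stronger inhibitor), compound 1 gives 4750 nM, and compound 2 gives 5100 nM. Compound 2 has the higher of the two numbers, but its nearest neighbour, compound 1, lies within the scatter of it, so the two cannot be told apart on this assay. Going by the values given here, with only two compounds measured, no step between them is on record, and the series offers no guide yet to what a change at the aromatic carbon does.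

Compound 3 `CCCCc1ccc(C(=O)/C=C/C(=O)O)cc1` differs from compound 2 in one place: butyl in place of tert-butyl on an aromatic carbon. The two have the same atoms joined differently, and neither group brings a donor or an acceptor. With nothing measured around this change, no step beyond the scatter is expected, and compound 3 is estimated at 6000 nM in this assay, between 2500 nM and 15000 nM, an expected step of a 1.2-fold higher number from compound 2 to compound 3 (0.07 log units; within the scatter).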

Compound 3, half-maximal inhibitory concentration: 4780 nM
Beside the measured number, compound 3's estimate is 1.3-fold (0.10 log units) above it; measured number inside the range.
By their numbers in this assay, from the lowest: compounds 1, 3 and 2 (each within the scatter of the next).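

Going by these compounds alone, this is the first step on record at this position. With butyl in place of tert-butyl on an aromatic carbon, para to a group of 7 heavy atoms, this assay gives a 1.1-fold lower number from compound 2 to compound 3 (0.03 log units; within the scatter) for the series. These two groups, with the same atoms joined differently, therefore cannot be told apart at this position in this assay and no measurement of another kind bears on this result.

The compounds shown leave open whether a group of another kind at this aromatic carbon, such as an amine, a carboxylic acid or a longer chain like octyl, would give a number beyond the scatter of compound 2. They also leave open what an amide in place of the carboxylic acid on the shared core would do.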